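Fluorine added to the phenyl on the ring nitrogen

This account rests on a few compounds, and the source may have more. Where it says the series, first, only, none or still open, it means among the compounds named here.

Measured compounds in a functional assay on HT-29 cells (Homo sapiens) for inhibition, read by MTT assay, with a stated time of 72 h; a lower number here means a stronger inhibitor, a higher number a weaker inhibitor:
compound 1 `COc1cc2c(Oc3ccc(NC(=O)c4nn(-c5ccccc5C(F)(F)F)c(=O)cc4C)cc3F)ccnc2cc1OCCCN1CCCC1` — compound 1 gives 140 nM
compound 2 `COc1cc2c(Oc3ccc(NC(=O)c4nn(-c5cccc(F)c5)c(=O)cc4C)cc3F)ccnc2cc1OCCCN1CCCC1` — compound 2 gives 250 nM
compound 3 `COc1cc2c(Oc3ccc(NC(=O)c4nn(-c5cccc(F)c5)c(=O)cc4C)cc3F)ccnc2cc1OCCCN1CCN(C)CC1` — compound 3 gives 250 nM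

Compound 2 sits level with compound 3 at the digits shown, the two of them the highest of the three numbers; the remaining gap among the three is a 1.8-fold higher number from compound 1 to compound 2 (0.25 log units; within the scatter), within the scatter, so no order among the three can be stated.

Compound 4 `COc1cc2c(Oc3ccc(NC(=O)c4nn(-c5ccc(F)c(F)c5)c(=O)cc4C)cc3F)ccnc2cc1OCCCN1CCCC1` differs from compound 2 by fluoro in place of hydrogen on an aromatic carbon. Of the measured steps, the one that bears on this place is a 1.8-fold higher number from compound 1 to compound 2 (0.25 log units; within the scatter), a change of the same phenyl group that stayed within the scatter; the step of no change at the digits printed from compound 2 to compound 3 (within the scatter), at the amine end, was likewise flat. Nothing measured here points to a shift beyond the scatter in this assay for a second fluoro on that ring. The expected step is therefore a 1.1-fold lower number from compound 2 to compound 4 (0.06 log units; within the scatter), essentially none. Compound 4 is estimated at 220 nM, with a range of 100 nM to 500 nM.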

Compound 4, half-maximal inhibitory concentration: 150 nM
Estimate against measurement, compound 4: 1.5-fold (0.17 log units) above; the measured number falls inside the stated range.
By their numbers in this assay, from the lowest: compounds 1, 4, 2 and 3 (each within the scatter of the next).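

In this assay, the ring on the nitrogen accepts a second fluoro, on the aromatic carbon ortho to the existing fluoro group, with a 1.7-fold lower number from compound 2 to compound 4 (0.22 log units; within the scatter). Against the 2-(trifluoromethyl)phenyl group, the 3,4-difluorophenyl group gives a 1.1-fold higher number from compound 1 to compound 4 (0.03 log units; within the scatter), so the three phenyl groups carried at this nitrogen by compound 1, compound 2 and compound 4 all read alike within the scatter. Nothing else available here bears on why the readings stay this close.

Still open, as far as these compounds go, is whether a carboxylic acid or an amine on this phenyl ring would stay within the scatter as the fluoro and trifluoromethyl groups do. Also open, from the compounds shown here alone, is whether the 3,4-difluorophenyl group would read the same with 4-methylpiperazin-1-yl in place of pyrrolidin-1-yl at the end of the chain.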